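This account rests on a few compounds, and the source may have more. Where it says the series, first, only, none or still open, it means among the compounds named here.

Working notes on the series. Compound 1 `O=C(Nc1ccccc1)Nn1c(-c2ccccc2)nc2ccccc2c1=O` is the reference; in a functional assay on the whole organism (strain albino) with Mus musculus as the target, at a dose of 100 mg/kg by the intraperitoneal route (a higher number here means more inhibition at the dose given (going by the name of the read-out), a lower number less inhibition), compound 1 gives 56%. For the measured compounds named here, compound 2 `CCOc1ccc(NC(=O)Nn2c(CC)nc3ccccc3c2=O)cc1` is the only other compound measured, and in this assay compound 2 gives 50%, a number that sits within the scatter of the value of compound 1, so no order between the two can be read. Compound 3 `Cc1cccc(NC(=O)Nn2c(-c3ccccc3)nc3ccccc3c2=O)c1` differs from compound 1 by methyl in place of hydrogen on an aromatic carbon. Going by the values given here, no measured pair in the set shows the effect of such a change, so the step from compound 1 to compound 3 is expected to stay within the scatter, as a number 1 percentage points lower from compound 1 to compound 3 (within the scatter). Compound 3 is accordingly estimated at 55%, in the range 40% to 70%.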

Compound 3, a percentage reported as inhibition, in the whole organism at one dose (the size of the read-out at that dose, not a potency): 59%
Estimate against measurement, compound 3: 4 percentage points below, within the range that was stated.
By their numbers in this assay, from the lowest: compounds 2, 1 and 3 (each within the scatter of the next).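

Methyl in place of hydrogen on an aromatic carbon, meta to a large group, is the first change in the series made in one place, and in this assay it reads as a number 3 percentage points higher from compound 1 to compound 3 (within the scatter). The phenyl of compound 1 can therefore become the 3-methylphenyl of compound 3 with no difference that can be read at this dose. Nothing at hand gives a reason for this result.

Still open, on these data alone, is whether a group other than methyl at this place, such as an amine, a carboxylic acid or a longer chain, would leave the value within the scatter. As far as these compounds go, the same methyl at other places on this ring also remains open.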